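Acyl-to-sulfonyl swap on a shared indazolyl-azaindole core

This account rests on a few compounds, and the source may have more. Where it says the series, first, only, none or still open, it means among the compounds named here.

Measured in a functional assay on SMMC-7721 cells (Homo sapiens) for antiproliferative activity, read by MTT assay, with a stated time of 72 h; on this read-out higher numbers stand for weaker inhibition and lower numbers for stronger inhibition:
- compound 1 `CCC(=O)N(C)c1ccc2[nH]c(-c3n[nH]c4ccccc34)cc2n1` gives 33500 nM
- compound 2 `CN(C(=O)c1ccco1)c1ccc2[nH]c(-c3n[nH]c4ccccc34)cc2n1` gives 28200 nM

Compound 2 and compound 1 lie within the scatter of each other; the step of a 1.2-fold lower number from compound 1 to compound 2 (0.07 log units; within the scatter) is the only one available. Compound 3 `CN(c1ccc2[nH]c(-c3n[nH]c4ccccc34)cc2n1)S(=O)(=O)c1ccc(Cl)cc1` differs from compound 2 by (4-chlorophenyl)sulfonyl in place of (furan-2-yl)carbonyl on a nitrogen on an aromatic ring. Within the data shown here, the single step at this nitrogen, furan-2-yl for ethyl on the carbonyl carbon, changed nothing beyond scatter; the move to a sulfonyl has no precedent here. No step beyond the scatter is expected in this assay for compound 3, which is estimated at 25000 nM (range 8000 nM to 80000 nM), a step of a 1.1-fold lower number from compound 2 to compound 3 (0.05 log units; within the scatter).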

Compound 3, half-maximal inhibitory concentration: 12700 nM
Beside the measured number, compound 3's estimate is 2.0-fold (0.29 log units) above it, and the stated range covers the measured number.
By their numbers in this assay, from the lowest: compound 3; then compounds 2 and 1 (each within the scatter of the next).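

In this assay, among these compounds, the move from a carbonyl to a sulfonyl at this nitrogen on an aromatic ring gives the first steps beyond the scatter: (4-chlorophenyl)sulfonyl gives (a 2.2-fold lower number from compound 2 to compound 3 (0.35 log units; beyond the scatter)) against (furan-2-yl)carbonyl and (a 2.6-fold lower number from compound 1 to compound 3 (0.42 log units; beyond the scatter)) against propanoyl. Both steps are modest, and all three compounds remain weak on this read-out. Nothing available explains the difference between the sulfonyl and the two carbonyl groups.

As far as these compounds go, the change swaps the linking group and the ring together, so it remains open which of them carries the step. A 4-chlorobenzoyl or a methanesulfonyl group on this nitrogen would separate the two.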